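The source may hold more compounds than are shown below. What is called first, only, known or untested is meant among the compounds shown, and "the series" means these compounds.

Working notes on the series. Compound 1 `COc1ccccc1/C=C/C(=O)OCc1nc(C)c(C)nc1C`, compound 2 `COc1ccc(/C=C/C(=O)OCc2nc(C)c(C)nc2C)cc1OC` and compound 3 `COc1ccc(OC)c(/C=C/C(=O)OCc2nc(C)c(C)nc2C)c1` are measured in a functional assay on PC-12 cells (Rattus norvegicus); a higher number here means that more compound is needed for the effect, a lower number that less compound is needed. Compound 1 reaches only a limit of the assay there, < 24000 nM. Compound 2 likewise sits at a limit, < 24000 nM. Compound 3 also returns a limit, < 24000 nM. The change methoxy in place of hydrogen on an aromatic carbon gives a step that the two limits leave unreadable from compound 1 to compound 3; this rests on (the limit of < 24000 nM in this assay, at which 3 of the 3 values shown sit). How the core of compound 1 and the core of compound 2 differ is not broken down here.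

Compound 4 `COc1ccc(/C=C/C(=O)OCc2nc(C)c(C)nc2C)c(OC)c1OC` is not yet measured. It arises from compound 2 by methoxy in place of hydrogen on an aromatic carbon, the same kind of change as from compound 1 to compound 3, though the surroundings differ: in the measured pair the methoxy enters meta to a large group and para to a methoxy group, in the new pair ortho to a large group, ortho to a methoxy group and meta to a methoxy group. Because the limit of < 24000 nM in this assay, at which 3 of the 3 values shown sit, holds for every value seen so far, the step from compound 2 to compound 4 in this assay is expected to be an at least 1.2-fold higher number from compound 2 to compound 4 (0.09 log units; that floor lies within the scatter). Compound 4 is estimated at 30000 nM, between 5000 nM and 100000 nM, most likely again only a limit.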

Compound 4, half-maximal effective concentration: 719 nM
Beside the measured number, compound 4's estimate is 42-fold (1.62 log units) above it, and the stated range ends above it.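

The value for compound 4 gives no readable step from compound 2 because compound 2 is represented only by a limit: the limit of < 24000 nM in this assay, at which 3 of the 4 values shown sit.

The compounds shown leave open how large the effect of methoxy in place of hydrogen on an aromatic carbon is in this assay, both between compound 1 and compound 3 and between compound 2 and compound 4.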